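A few compounds are considered here, and "the series" means these few. Any claim that something is new, unique, unknown or untested is made for them only; others in the source may bear on it.

Working notes on the series.

Compound 3 `CCCc1nc(C)c2cnn(C)c(=O)n12` gives 20000 nM in a functional assay for inhibition, with Homo sapiens as the target; on this read-out higher numbers stand for weaker inhibition and lower numbers for stronger inhibition. Compound 1 `CCCc1nc(C)c2c(C)nn(C)c(=O)n12` returns only a limit in this assay, > 48000 nM, not a number. The change between them is methyl in place of hydrogen on an aromatic carbon, and it gives an at least 2.4-fold higher number from compound 3 to compound 1 (0.38 log units; beyond the scatter); of the numbers shown, two sit at the limit of > 48000 nM in this assay, at which 2 of the 3 values shown sit, so the size of this step is known only as a lower bound.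

Compound 2 `CNc1nncc2cncn12` also returns only a limit in this assay, > 48000 nM. The difference between the core of compound 2 and the core of compound 3 is not broken down here.

Compound 4 `CNc1nncc2c(C)ncn12` is yet to be measured. It differs from compound 2 by methyl in place of hydrogen on an aromatic carbon. Among the measured compounds shown here, this is the same kind of change as the one from compound 3 to compound 1, not the same change: in compound 1 the methyl sits on an aromatic carbon of a six-membered aromatic ring with 3 nitrogen, ortho to a fused ring, meta to a methyl group and para to a group of 1 heavy atom, whereas in compound 4 it sits on an aromatic carbon of a five-membered aromatic ring with 2 nitrogen.

For the measured compounds named here, compound 2 already stands at the limit, and the same kind of change raised the number from compound 3 to compound 1 rather than lowering it; the step to compound 4 is therefore expected to be no better than a step that the limit leaves unreadable from compound 2 to compound 4. Compound 4 is expected to give about 100000 nM in this assay, between 40000 nM and 300000 nM, most likely reported only as a limit.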

Compound 4, half-maximal inhibitory concentration: > 48000 nM
Compound 4 gave a limit, no number (the forecaster's own chance of this, stated with the estimate: 90%); the middle value lies beyond the limit too.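

No step can be read from compound 2 to compound 4, because both compounds return only a limit and no number: the limit of > 48000 nM in this assay, at which 3 of the 4 values shown sit.

The compounds shown leave open whether methyl in place of hydrogen on the aromatic carbon of the five-membered aromatic ring with 2 nitrogen changes inhibition at all, and whether any such change runs in the same direction as that from compound 3 to compound 1.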